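Bromo for chloro, carried onto a second core

This account rests on a few compounds, and the source may have more. Where it says the series, first, only, none or still open, it means among the compounds named here.

Three compounds have been measured in an assay on tissue (HeLa cells) for inhibition of Indoleamine 2,3-dioxygenase 1 (Homo sapiens), read by spectrophotometry; on this read-out lower numbers stand for stronger inhibition and higher numbers for weaker inhibition:
compound 1, `OCc1cc2cc(/C(=N\O)Nc3cccc(Cl)c3)ccc2o1`: 5900 nM
compound 2, `OCc1cc2cc(/C(=N\O)Nc3cccc(Br)c3)ccc2o1`: 1200 nM
compound 3, `O/N=C(/Nc1cccc(Cl)c1)c1ccc2oc(-c3ccccc3)cc2c1`: 10800 nM

Compounds 1 and 2 share a core and differ only by bromo in place of chloro on an aromatic carbon; this gives a 4.9-fold lower number from compound 1 to compound 2 (0.69 log units; beyond the scatter). Compounds 1 and 3 differ in the core itself, by phenyl in place of hydroxymethyl on an aromatic carbon, and the two values lie close: a 1.8-fold higher number from compound 1 to compound 3 (0.26 log units; within the scatter).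

Compound 4, `O/N=C(/Nc1cccc(Br)c1)c1ccc2oc(-c3ccccc3)cc2c1`, is not yet measured. It stands to compound 3 as compound 2 stands to compound 1, the change being (bromo in place of chloro on an aromatic carbon); the place of the change is described in the same words for both pairs, so it is the same change on a different core.

The expectation for compound 4 rests on one precedent only, the step from compound 1 to compound 2 of a 4.9-fold lower number from compound 1 to compound 2 (0.69 log units; beyond the scatter); with a single case the repeat on the core of compound 3 is taken as likely but not certain to be of full size, so the expected step is a 3.9-fold lower number from compound 3 to compound 4 (0.59 log units; beyond the scatter). Compound 4 is thus estimated at 2800 nM, with a range from 1000 nM to 7500 nM.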

Compound 4, half-maximal inhibitory concentration: 8600 nM
Compound 4: the middle estimate sits 3.1-fold (0.49 log units) below what was measured, and the stated range ends below it.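

In this assay, bromo in place of chloro gives a 1.3-fold lower number from compound 3 to compound 4 (0.10 log units; within the scatter), so the step seen on the core of compound 1 does not carry over at full size to the core of compound 3: the same change on two cores in this assay, a 4.9-fold lower number (0.69 log units; beyond the scatter) from compound 1 to compound 2 and a 1.3-fold lower number (0.10 log units; within the scatter) from compound 3 to compound 4, 3.9-fold (0.59 log units) apart, beyond the scatter of two such steps Read the other way, phenyl in place of hydroxymethyl gives a 7.2-fold higher number from compound 2 to compound 4 (0.86 log units; beyond the scatter), and the two changes do not add independently across these four compounds: the same change on two cores in this assay, a 1.8-fold higher number (0.26 log units; within the scatter) from compound 1 to compound 3 and a 7.2-fold higher number (0.86 log units; beyond the scatter) from compound 2 to compound 4, 3.9-fold (0.59 log units) apart, beyond the scatter of two such steps This shows that the bromo step depends on the core in this set, but with one pair per core it does not show which core gives the more usual result, nor why the steps differ.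

Open, from the compounds shown here alone, is whether the step from chloro to bromo on the core of compound 1 would recur with a further halogen such as iodo, or with a small carbon group such as methyl, in the same place. Also open, going by these compounds, is how far the dependence on the core extends when an amine or a carboxylic acid stands in place of hydroxymethyl or phenyl.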